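The compounds below may be only part of what the source reports. "The series", "measured", "known", "first", "only" and "open" are said of these compounds alone.

Working notes on the series. Three compounds have been run in a physicochemical assay for metabolic stability, read by LC-MS, in phosphate buffer, with a stated time of 3 h, at pH 7.4, tested at 50 uM (a lower number here means that less of the compound is left, a higher number that more of the compound is left), so far, all on the shared core of compound 1 `Cc1oc(=O)oc1COC(=O)c1cccc(NC(=O)[C@@H]2C[C@H](SC3=C(C(=O)O)N4C(=O)[C@H]([C@@H](C)O)[C@H]4[C@H]3C)CN2)c1`. In this assay compound 1 gives > 95%, which is a limit of the assay and not a number. Compound 2 `C[C@@H](O)[C@H]1C(=O)N2C(C(=O)OCOC(=O)C3CCCCC3)=C(S[C@@H]3CN[C@H](C(=O)Nc4cccc(C(=O)O)c4)C3)[C@H](C)[C@H]12` gives > 95% in this assay, again a limit. Compound 3 `CCOC(=O)OCOC(=O)C1=C(S[C@@H]2CN[C@H](C(=O)Nc3cccc(C(=O)OCOC(=O)OCC)c3)C2)[C@H](C)[C@@H]2[C@@H]([C@@H](C)O)C(=O)N12` gives > 95% in this assay, also a limit. Compound 3 therefore stands only at a limit, as do the two other values shown; the whole set sits at the limit of > 95% in this assay, at which 3 of the 3 values shown sit. Among the measured compounds shown here, no pair of measured compounds differs in one place, so no measured step is available to lean on.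

Compound 4 `CCOC(=O)OCOC(=O)C1=C(S[C@@H]2CN[C@H](C(=O)Nc3cccc(C(=O)O)c3)C2)[C@H](C)[C@@H]2[C@@H]([C@@H](C)O)C(=O)N12` is to be measured in this assay. It differs from compound 3 by hydrogen in place of ((ethoxycarbonyl)oxy)methyl on an oxygen next to a carbonyl group. Compound 4 keeps the other ((ethoxycarbonyl)oxy)methyl of compound 3. The expected step from compound 3 to compound 4 is a step that the limit leaves unreadable from compound 3 to compound 4, none beyond the scatter, and compound 4 is expected to return a limit because of the limit of > 95% in this assay, at which 3 of the 3 values shown sit. The estimate for compound 4 is 96%, within 90% to 100%.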

Compound 4, percent of the compound remaining: > 95%
Compound 4: only a limit was reported; the forecaster's own chance of this, stated with the estimate: 80%; the middle value lies beyond the limit too.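

Compound 4 gives > 95% in this assay, which is a limit of the assay and not a number. The steps from compound 3 and from compound 2 to compound 4 therefore cannot be read. The compounds shown leave open how far they differ in percent remaining, with all of them at one limit: the limit of > 95% in this assay, at which 4 of the 4 values shown sit.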